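Swapping a furan for a phenyl on a shared pyridine-free core

The compounds below may be only part of what the source reports. "The series", "measured", "known", "first", "only" and "open" are said of these compounds alone.

Of the compounds shown here, three built on a shared core have been tested in a functional assay on DU-145 cells (Homo sapiens) for cytotoxicity, read by CCK-8 assay and cell counting, with a stated time of 2 days; a higher number here means a weaker inhibitor, a lower number a stronger inhibitor. Compound 3 `Oc1ccc(-c2cc(-c3cccc(Cl)c3)nc(-c3ccco3)c2)cc1` gives 5750 nM, the highest of the three numbers. Compound 2 `Oc1ccc(-c2cc(-c3cccc(Cl)c3)nc(-c3cccs3)c2)cc1` gives 5740 nM, and the change a 1.0-fold higher number from compound 2 to compound 3 (0.00 log units; within the scatter) shows that exchanging one five-membered aromatic ring with 1 hetero atom for another made no difference beyond the scatter. Compound 1 `Oc1ccc(-c2cc(-c3ccccc3)nc(-c3ccccc3Cl)c2)cc1`, which carries a phenyl and a 2-chlorophenyl on the core, gives 2800 nM, a lower number than compound 3 by a margin beyond the scatter.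

Compound 4 `Oc1ccc(-c2cc(-c3ccccc3)nc(-c3cccc(Cl)c3)c2)cc1` arises from compound 3 by phenyl in place of furan-2-yl on an aromatic carbon. Going by the values given here, no measured step covers exactly this exchange; the only phenyl-bearing compound, compound 1, differs from compound 4 in where its chlorine sits, so its value can guide but not fix the expectation. Because compound 1 gives 2800 nM with a phenyl in this spot, compound 4 is expected to show a modest move toward a lower number, a 1.6-fold lower number from compound 3 to compound 4 (0.22 log units; within the scatter). The estimate for compound 4 in this assay is 3500 nM, with a range from 1500 nM to 8000 nM.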

Compound 4, half-maximal inhibitory concentration: 5360 nM
Beside the measured number, compound 4's estimate is 1.5-fold (0.19 log units) below it; the range from low to high includes it.
By their numbers in this assay, from the lowest: compounds 1, 4, 2 and 3 (each within the scatter of the next, the first and the last beyond it).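

In this assay the position next to the ring nitrogen now holds three different aromatic rings with the 3-chlorophenyl group kept in place, and the phenyl reads like both five-membered rings, with a 1.1-fold lower number from compound 3 to compound 4 (0.03 log units; within the scatter) and a 1.1-fold lower number from compound 2 to compound 4 (0.03 log units; within the scatter) as the two steps. Exchanging 2-chlorophenyl for 3-chlorophenyl gives a 1.9-fold higher number from compound 1 to compound 4 (0.28 log units; within the scatter) and so also stays within the scatter, which means that neither change shifts the number by a readable amount. No evidence is at hand that bears on this result.

From the compounds shown here alone, what an amine, a carboxylic acid or a longer alkyl chain would do at the position next to the ring nitrogen stays open. Also open is how much the 4-hydroxyphenyl group contributes, as it is the same in every compound shown.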